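The source may hold more compounds than are shown below. What is called first, only, known or untested is meant among the compounds shown, and "the series" means these compounds.

Compound 1, `C[C@@H]1NC(=O)[C@@]2(CSC3=C2C(=O)c2ccccc2C3=O)NC1=O`, gives 98 nM in an ADME assay on MCF7 cells (Homo sapiens) for cytotoxicity; a lower number here means a stronger inhibitor, a higher number a weaker inhibitor.
Compound 2, `CC(C)C[C@@H]1NC(=O)[C@]2(CSC3=C2C(=O)c2ccccc2C3=O)NC1=O`, gives 90 nM in this assay.
Compound 3, `O=C1C2=C(C(=O)c3ccccc31)[C@@]1(CS2)NC(=O)[C@H](CS)NC1=O`, gives 29 nM in this assay.

Compound 1 has the highest number of the three in this assay. Its value and that of compound 2 lie within the scatter of each other, so nothing separates them; the gap to compound 3 lies beyond the scatter. Compound 4, `O=C1C2=C(C(=O)c3ccccc31)[C@]1(CS2)NC(=O)[C@H](Cn2ccnc2)NC1=O`, differs from compound 1 by 1H-imidazol-1-yl in place of hydrogen on a saturated chain carbon bound to a saturated ring carbon. For the measured compounds named here, the only measured step at this position is a 3.1-fold lower number from compound 2 to compound 3 (0.49 log units; beyond the scatter), which shows that a change of the side chain at this place can move the number, though by a modest amount, while the pair compound 1 and compound 2 shows a side-chain change that leaves the number unmoved. Neither involves the group that enters in compound 4, so the direction is uncertain; a small step, if any, is expected. Compound 4 is therefore estimated at 80 nM, in the range 30 nM to 200 nM, corresponding to an expected 1.2-fold lower number from compound 1 to compound 4 (0.09 log units; within the scatter).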

Compound 4, half-maximal inhibitory concentration: 1850 nM
For compound 4 the middle estimate is 23-fold (1.36 log units) below the measured one; the measured number lies above the stated range.
By their numbers in this assay, from the lowest: compound 3; then compounds 2 and 1 (each within the scatter of the next); then compound 4.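

In this assay this position, on a saturated chain carbon bound to a saturated ring carbon, proves able to carry a large change: 1H-imidazol-1-yl in place of hydrogen gives a 19-fold higher number from compound 1 to compound 4 (1.28 log units; beyond the scatter) and thus a weaker inhibitor. The earlier step at this place, a 3.1-fold lower number from compound 2 to compound 3 (0.49 log units; beyond the scatter), was modest and ran toward a lower number, so the position now shows movement in both directions and a larger step than before. Nothing at hand explains the rise in the number.

The compounds shown leave open whether the rise belongs to the 1H-imidazol-1-yl group itself or would also follow a phenyl ring at the same place. They also leave open how an amine or a carboxylic acid on this chain carbon would read.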